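A few compounds are considered here, and "the series" means these few. Any claim that something is new, unique, unknown or untested is made for them only; others in the source may bear on it.

Of the compounds shown here, two have been tested in a functional assay on CHO cells for antagonist activity at prostaglandin E2 receptor EP4 subtype (Homo sapiens), read by calcium flux, with a stated time of 15 min (on this read-out higher numbers stand for weaker inhibition and lower numbers for stronger inhibition), so far. Compound 1 `CCc1c(C(=O)N[C@@H](C)c2ccc(C(=O)O)cc2)nnn1Cc1ccc(C(F)(F)F)cc1` carries an ethyl group on its five-membered ring. In this assay compound 1 gives > 10000 nM, which is a limit of the assay rather than a number. Compound 2 `Cc1nnn(Cc2ccc(C(F)(F)F)cc2)c1C(=O)N[C@@H](C)c1ccc(C(=O)O)cc1` carries a methyl group in the same position. In this assay compound 2 gives > 10000 nM, again a limit rather than a number. Compound 2 therefore stands at the limit of > 10000 nM in this assay, at which 2 of the 2 values shown sit, with no measured value to rank it against compound 1. Compound 3 `C[C@H](NC(=O)c1c(-c2ccc(F)cc2)nnn1Cc1ccc(C(F)(F)F)cc1)c1ccc(C(=O)O)cc1` has not yet been measured; it differs from compound 2 by 4-fluorophenyl in place of methyl on an aromatic carbon. Among the measured compounds shown here, since no measured step exists, the direction of the change can only be estimated. The step from compound 2 to compound 3 in this assay is expected to be an at least 5.0-fold lower number from compound 2 to compound 3 (0.69 log units; beyond the scatter). For compound 3 an inhibitory concentration of about 2000 nM is expected in this assay, within a range of 200 nM to 20000 nM.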

Compound 3, half-maximal inhibitory concentration: 57.9 nM
Compound 3: middle estimate off by 35-fold (1.54 log units), on the high side, outside the stated range (below it).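

This position on the five-membered aromatic ring with 3 nitrogen turns out to respond strongly to the group it carries: in this assay, 4-fluorophenyl in place of methyl gives an at least 170-fold lower number from compound 2 to compound 3 (2.23 log units; beyond the scatter). The full size of this step cannot be read, since compound 2 has a limit of the assay and not a number: the limit of > 10000 nM in this assay, at which 2 of the 3 values shown sit. Compound 1, with ethyl on the same ring carbon, also has only a limit of the assay, > 10000 nM, so going from methyl to ethyl shows no measurable change on this read-out.

The compounds shown leave open whether the change depends on the fluorine or on the six-membered aromatic ring alone, which a plain phenyl group would separate. They also do not show whether a 4-chlorophenyl group, a pyridine ring or a cyclohexyl group would serve equally well at this position.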